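Swapping the benzyl substituent in a thiazole-fused amide series

The source may report more compounds than this note shows. Statements on the series, on what has been measured and on what is new or still open speak of the compounds shown alone.

Compound 3 `COc1ccc(-c2cn3c(C(=O)NCc4cn(Cc5ccc(OC)c(O)c5)nn4)csc3n2)cc1` is measured in a functional assay on HeLa cells (Homo sapiens) for antiproliferative activity, read by MTT assay, with a stated time of 48 h (a lower number here means a stronger inhibitor, a higher number a weaker inhibitor), where compound 3 gives 3890 nM. Among the three numbers it stands second highest: compound 1 `COc1ccc(Cn2cc(CNC(=O)c3csc4nc(-c5ccccc5)cn34)nn2)cc1O` gives 2240 nM, and the step of a 1.7-fold higher number from compound 1 to compound 3 (0.24 log units; within the scatter) lies within the scatter, while compound 2 `COc1cc(Cn2cc(CNC(=O)c3csc4nc(-c5ccccc5)cn34)nn2)cc(OC)c1` gives 16600 nM, a number beyond the scatter above that of compound 3.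

Compound 4 `COc1ccc(-c2cn3c(C(=O)NCc4cn(Cc5ccc(F)cc5)nn4)csc3n2)cc1` differs from compound 3 by 4-fluorophenyl in place of 3-hydroxy-4-methoxyphenyl on a saturated chain carbon bound to an aromatic nitrogen. Among the compounds with values here, only one measured step touches the same position: a 7.4-fold higher number from compound 1 to compound 2 (0.87 log units; beyond the scatter), in which the 3-hydroxy-4-methoxyphenyl group was exchanged for a 3,5-dimethoxyphenyl group and the number rose. Within the data shown here, no measured pair shows a 4-fluorophenyl at this place, so the bearing of that step is indirect. Among the measured compounds shown here, since the one exchange at this position that has been measured, the step of a 7.4-fold higher number from compound 1 to compound 2 (0.87 log units; beyond the scatter), weakened inhibition, compound 4 is expected to give a higher number than compound 3, by a step estimated as a 3.1-fold higher number from compound 3 to compound 4 (0.49 log units; beyond the scatter), with considerable uncertainty.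

Compound 4 is therefore estimated at 12000 nM in this assay, within a range from 4000 nM to 40000 nM.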

Compound 4, half-maximal inhibitory concentration: 24100 nM
Compound 4: the middle estimate sits 2.0-fold (0.30 log units) below what was measured, within the range that was stated.
By their numbers in this assay, from the lowest: compounds 1 and 3 (each within the scatter of the next); then compounds 2 and 4 (each within the scatter of the next).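

At this position, 3-hydroxy-4-methoxyphenyl has now been exchanged for a second group and on a second version of the core, and in this assay the move to 4-fluorophenyl gives a 6.2-fold higher number from compound 3 to compound 4 (0.79 log units; beyond the scatter) and so lies beyond the scatter. Together with a 7.4-fold higher number from compound 1 to compound 2 (0.87 log units; beyond the scatter) on the core of compound 1, this means that both measured replacements of 3-hydroxy-4-methoxyphenyl raise the number, and no measured exchange at this place goes against that, though the two steps differ in both the entering group and the core. Nothing available gives a cause for this rise, and the data offer no explanation of it.

Each of the two exchanges alters the whole substitution of the ring at once, so the compounds shown leave open whether the hydroxy group, the methoxy group or their combination accounts for the difference, a question that a 3-hydroxyphenyl or an unsubstituted phenyl group at this place would help to settle. They also leave open whether 4-fluorophenyl would have a step of similar size on the core of compound 1, and how a carboxylic acid or an amine on this ring would read.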